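This account rests on a few compounds, and the source may have more. Where it says the series, first, only, none or still open, it means among the compounds named here.

In a functional assay on MT2 cells (Homo sapiens) for cytotoxicity (a higher number here means that more compound is tolerated, a lower number that less compound is tolerated), three compounds with a shared core have been measured. Compound 1 `CC(C)=CCOc1cc(Nc2nccs2)ccc1C` gives 17000 nM in this series, compound 2 `CC(C)=CCOc1cccc(Nc2nccs2)c1` gives 23000 nM in the same read-out, and compound 3 `CCc1ccc(Nc2nccs2)cc1OCC=C(C)C` gives 31000 nM and so stands level with both others. The measured steps show this: a 1.3-fold higher number from compound 2 to compound 3 (0.13 log units; within the scatter) and a 1.8-fold higher number from compound 1 to compound 3 (0.26 log units; within the scatter) are both small. Compound 4 `COc1ccc(Nc2nccs2)cc1OCC=C(C)C` differs from compound 3 in one place, methoxy in place of ethyl on an aromatic carbon and so carries methoxy in place of ethyl on an aromatic carbon, para to a (1,3-thiazol-2-yl)amino group. Going by the values given here, no measured step makes this exchange, so the evidence is indirect. At this same carbon, a 1.3-fold higher number from compound 2 to compound 3 (0.13 log units; within the scatter) is the step for ethyl in place of hydrogen, and a 1.4-fold higher number from compound 1 to compound 2 (0.13 log units; within the scatter) is the step for hydrogen in place of methyl. Neither leaves the scatter, so no step beyond the scatter is expected. The expected step is a 1.3-fold lower number from compound 3 to compound 4 (0.13 log units; within the scatter) and remains a rough estimate. Compound 4 is estimated at 23000 nM with an expected range from 11000 nM to 48000 nM for its measurement.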

Compound 4, half-maximal cytotoxic concentration: 42000 nM
For compound 4 the middle estimate is 1.8-fold (0.26 log units) below the measured one; low and high end bracket the measured number.
By their numbers in this assay, from the lowest: compounds 1, 2, 3 and 4 (each within the scatter of the next, the first and the last beyond it).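

In this assay methoxy on the carbon para to a (1,3-thiazol-2-yl)amino group gives a 1.4-fold higher number from compound 3 to compound 4 (0.13 log units; within the scatter) against ethyl and a 1.8-fold higher number from compound 2 to compound 4 (0.26 log units; within the scatter) against hydrogen, so neither exchange separates these groups at this position. Going by these compounds alone, only methoxy in place of methyl gives a 2.5-fold higher number from compound 1 to compound 4 (0.39 log units; beyond the scatter) and so leaves the scatter, modestly, which makes it the first step at this carbon to do so. Nothing at hand gives a reason for this difference.

The compounds shown leave open whether an amine, a carboxylic acid or a longer alkoxy chain on this carbon would move the number further than methoxy does. They also leave open whether the difference between methoxy and methyl would persist if the (3-methylbut-2-en-1-yl)oxy group were replaced by a shorter chain such as ethoxy.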